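A few compounds are considered here, and "the series" means these few. Any claim that something is new, unique, unknown or untested is made for them only; others in the source may bear on it.

Compound 1 `COc1cccc(OC)c1C(=O)NCCNc1nc2cc(C)cc(C)c2cc1C#N` gives 3700 nM in an in vitro assay on FRT cells with Cystic fibrosis transmembrane conductance regulator variant F508del (Homo sapiens) as the target, read by fluorescence, with a stated time of 24 h, at 37 degrees C, in the presence of a further agent that is not named here; on this read-out lower numbers stand for an effect already at smaller amounts and higher numbers for an effect only at larger amounts of compound; compound 2 `COc1ccccc1C(=O)NCCCNc1nc2cc(C)cc(C)c2cc1C#N` gives "not active" (no number reported) in this assay.

Compound 2 thus stands without a number: in this assay it was reported as inactive, and only compound 1 carries a measured value. Compound 3 `COc1cccc(C(=O)NCCCNc2nc3cc(C)cc(C)c3cc2C#N)c1` differs from compound 2 in one place, (3-methoxyphenyl in place of 2-methoxyphenyl on a carbonyl carbon). Among the measured compounds shown here, no step between measured compounds is available for this change, so the expected size of the step in this assay cannot be drawn from data here; compound 2 being inactive gives the starting point. Compound 3 is expected to show at best weak activity, estimated at 12000 nM with a range from 2500 nM to 60000 nM.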

Compound 3, half-maximal effective concentration: 4600 nM
The estimate for compound 3 lay 2.6-fold (0.42 log units) above the measured number; the measured number falls inside the stated range.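

Among the compounds shown here, compound 2 carries no number, so no step from it to compound 3 can be read. Nothing available accounts for the result. The compounds shown leave open how much 3-methoxyphenyl in place of 2-methoxyphenyl changes the read-out.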